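Dibenzoylhydrazine ecdysone agonists: a ring swap on the hydrazide side

This account rests on a few compounds, and the source may have more. Where it says the series, first, only, none or still open, it means among the compounds named here.

Compound 1, `CC(C)(C)N(NC(=O)c1ccccc1)C(=O)c1ccccc1F`: 309 nM
Compound 2, `CC(C)(C)N(NC(=O)c1cccc(F)c1)C(=O)c1ccccc1Cl`: 69.2 nM

Both measured compounds share a core in which a tert-butyl group sits on a hydrazide that carries two aromatic carbonyl groups. In an assay on cells for agonist activity at ecdysone receptor (Bombyx mori), read by a luciferase reporter, with a stated time of 24 h (a higher number here means that more compound is needed for the effect, a lower number that less compound is needed), compound 1 gives 309 nM, and in this assay compound 2 gives 69.2 nM. Of the two numbers, compound 2 holds the lower one, with compound 1 standing well apart from it, beyond the usual scatter. For the measured compounds named here, no pair differing in a single place has been measured, so no step in this assay is known from experiment.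

Compound 3, `Cc1ccc(C)c(C(=O)NN(C(=O)c2ccccc2Cl)C(C)(C)C)c1`, has not yet been measured. It departs from compound 2 in one place: 2,5-dimethylphenyl in place of 3-fluorophenyl on a carbonyl carbon. The two measured compounds differ in more than one place. Nothing in the numbers shows how a change on this carbonyl carbon alone shifts this assay.

The change is expected to leave the number near that of compound 2, or to lower it modestly, with the step from compound 2 to compound 3 estimated at a 1.5-fold lower number from compound 2 to compound 3 (0.19 log units; within the scatter). For compound 3 the estimate in this assay is 45 nM, within a range of 12 nM to 180 nM.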

Compound 3, half-maximal effective concentration: 1620 nM
Beside the measured number, compound 3's estimate is 36-fold (1.56 log units) below it; the measured number lies above the stated range.
By their numbers in this assay, from the lowest: compound 2; then compound 1; then compound 3.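

In this assay, the change of 3-fluorophenyl to 2,5-dimethylphenyl on this carbonyl carbon gives a 23-fold higher number from compound 2 to compound 3 (1.37 log units; beyond the scatter), and this is the only step shown in which just one place differs. It shows that this position is far from indifferent to which substituted aromatic ring it carries: both groups have a six-membered aromatic ring of carbon only, neither has hydrogen-bond donors or acceptors, and neither has a net charge, yet the number still moves well beyond the usual scatter. Those shared features therefore cannot account for the difference between the two compounds, and no measurement is available to explain the step.

This single step cannot separate the loss of the fluorine from the arrival of the two methyl groups, nor show whether either methyl group matters more than the other. Keeping the rest of compound 2 and placing a methoxy group or a nitrile on this ring would test how the number responds to other substituents, and so whether compound 2 or compound 3 is the more typical case.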